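The source may report more compounds than this note shows. Statements on the series, on what has been measured and on what is new or still open speak of the compounds shown alone.

In a functional assay on HL-60 cells (Homo sapiens) for cytotoxicity, read by XTT assay, with a stated time of 72 h (a higher number here means a weaker inhibitor, a lower number a stronger inhibitor), three compounds have been tested so far. Compound 1 `COc1cc(C(O)c2ccc3c(ccn3C)c2)cc(OC)c1OC` is recorded at > 10000 nM, which is a limit of the assay and not a number. Compound 2 `CCn1ccc2cc(C(=O)c3cc(OC)c(OC)c(OC)c3)ccc21` gives a measured value of 34 nM. As far as these compounds go, compound 3 `CCn1ccc2cc(/C(=N\O)c3cc(OC)c(OC)c(OC)c3)ccc21` stands at > 1000 nM, which is also a limit, so its true position in this assay remains unknown.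

Compound 4 `CCn1ccc2cc(/C(=N\N)c3cc(OC)c(OC)c(OC)c3)ccc21` differs from compound 3 at a single place: amino in place of hydroxy on a double-bonded nitrogen. It carries amino in place of hydroxy on a double-bonded nitrogen. For the measured compounds named here, no measured pair in this set shows this change directly, so any expectation is loose. Compound 2, at 34 nM, shows that a close relative of compound 4 can give a measured value in this assay, and this favours a move towards stronger inhibition. A result without a measured value also remains possible for compound 4. The expected change is an at least 3.3-fold lower number from compound 3 to compound 4 (0.52 log units; beyond the scatter), a step of uncertain size. For compound 4, the estimated value is 300 nM, with an expected range from 30 nM to 3000 nM.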

Compound 4, half-maximal inhibitory concentration: > 1000 nM
Compound 4: a limit, no number; the forecaster's own chance of this, stated with the estimate: 25%; at least 3.3-fold (0.52 log units) between middle value and limit.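

Compound 4, at > 1000 nM, stands at a limit of the assay and not a number. Compound 3 also stands at a limit, so no step can be read between compound 3 and compound 4. The compounds shown leave open whether amino or hydroxy on a double-bonded nitrogen gives the stronger inhibition in this assay.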